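This account rests on a few compounds, and the source may have more. Where it says the series, first, only, none or still open, it means among the compounds named here.

Measured so far in an assay on HL-60 cells for agonist activity at N-formyl peptide receptor 3 (Homo sapiens), read by calcium flux; a higher number here means that more compound is needed for the effect, a lower number that less compound is needed:
Compound 1 `COc1cccc(Cc2ccnn(CC(=O)Nc3ccc(Br)cc3)c2=O)c1` gives 14600 nM.
Compound 2 `Cc1cc(Cc2cccc(F)c2)c(=O)n(CC(=O)Nc2ccc(Br)cc2)n1` gives only a limit, > 50000 nM.
Compound 3 `CC1=NN(CC(=O)Nc2ccc(I)cc2)C(=O)CC1` gives only a limit, > 50000 nM.

Of the three compounds, only compound 1 gives a number in this assay. Compound 2 stands at the edge of what the assay reports: its result is a limit and not a number, so the amount of compound 2 needed for the effect is not known, only that it exceeds what the assay can report. Compound 3 sits at the same limit. Among the compounds with values here, two of the three values therefore share one limit (the limit of > 50000 nM in this assay, at which 2 of the 3 values shown sit), and no pair of measured compounds differs in just one place, so no measured step is available to weigh the change that follows.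

Compound 4 `COc1ccc(Nc2cc(C)nn(CC(=O)Nc3ccc(Br)cc3)c2=O)cc1` is the next compound. It differs from compound 2 in a single place: (4-methoxyphenyl)amino in place of 3-fluorobenzyl on an aromatic carbon. A (4-methoxyphenyl)amino group now stands where the 3-fluorobenzyl group stood on the aromatic carbon of the shared core. Since compound 2 gives only a limit, the step is expected as a move from the limit toward a reportable number, an at least 2.5-fold lower number from compound 2 to compound 4 (0.39 log units; beyond the scatter), with little certainty about its size. Compound 4 is therefore estimated at 20000 nM, in a range from 4000 nM to 60000 nM.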

Compound 4, half-maximal effective concentration: > 50000 nM
Compound 4 gave a limit, no number (the forecaster's own chance of this, stated with the estimate: 45%); at least 2.5-fold (0.39 log units) between middle value and limit.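

Compound 2 and compound 4 each give only a limit, not a number, in this assay, and the step between them cannot be read: the limit of > 50000 nM in this assay, at which 3 of the 4 values shown sit.

The compounds shown leave open whether 3-fluorobenzyl and (4-methoxyphenyl)amino differ at all in how much compound is needed for the effect in this assay.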